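A few compounds are considered here, and "the series" means these few. Any claim that something is new, unique, unknown or untested is made for them only; others in the source may bear on it.

Measured so far in a functional assay on HeLa cells (Homo sapiens) for inhibition, read by MTT assay, with a stated time of 24 h; a lower number here means a stronger inhibitor, a higher number a weaker inhibitor:
- compound 1 `CCOC(=O)C1=Cc2ccccc2OC1(OCc1cn(-c2ccc(C)cc2)nn1)C(F)(F)F`: 25100 nM
- compound 2 `O=C(O)C1=Cc2ccccc2OC1(OCc1cc(-c2ccc([N+](=O)[O-])cc2)no1)C(F)(F)F`: > 150000 nM
- compound 3 `CCCCCCCCn1cc(COC2(C(F)(F)F)Oc3ccccc3C=C2C(=O)OCC)nn1`: > 150000 nM

Compound 2 shows only a limit of this assay, > 150000 nM. Compound 3 likewise shows only a limit, > 150000 nM, so compound 3 stands at the limit of > 150000 nM in this assay, at which 2 of the 3 values shown sit. For the measured compounds named here, the one single-change step, an at least 5.9-fold higher number from compound 1 to compound 3 (0.77 log units; beyond the scatter), runs from a number into that limit.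

Compound 4 `CCOC(=O)C1=Cc2ccccc2OC1(OCc1cn(CC(=O)Nc2ccc(I)cc2Cl)nn1)C(F)(F)F` differs from compound 3 by (2-chloro-4-iodophenyl)carbamoyl in place of heptyl on a saturated chain carbon bound to an aromatic nitrogen. Going by the values given here, no measured step touches this change; the only step known replaces octyl with 4-methylphenyl on the aromatic nitrogen, which is a different substituent from the (2-chloro-4-iodophenyl)carbamoyl entering here. With compound 3 at a limit, no direction can be read from the data; compound 4 is expected near 120000 nM, within 30000 nM to 400000 nM. The step of an at least 1.2-fold lower number from compound 3 to compound 4 (0.09 log units; that floor lies within the scatter) is therefore expected to stay within the scatter, with a fair chance that compound 4 again reports only a limit.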

Compound 4, half-maximal inhibitory concentration: 26100 nM
Compound 4: middle estimate off by 4.6-fold (0.66 log units), on the high side; the measured number lies below the stated range.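

In this assay, ((2-chloro-4-iodophenyl)carbamoyl)methyl in place of octyl on the aromatic nitrogen gives an at least 5.7-fold lower number from compound 3 to compound 4 (0.75 log units; beyond the scatter). Compound 3 is only a limit of the assay, so that step is a floor: the limit of > 150000 nM in this assay, at which 2 of the 4 values shown sit. Against 4-methylphenyl on the same nitrogen, the change gives a 1.0-fold higher number from compound 1 to compound 4 (0.02 log units; within the scatter), so these two ring-bearing groups are not told apart here, and octyl alone of the three sits at the limit.

Still open, going by these compounds, is whether the amide hydrogen, the carbonyl, the chlorine or the iodine of compound 4 matters. Also open, on these data alone, is how a shorter chain such as butyl, or a benzyl or unsubstituted phenyl on that nitrogen, would read in this assay.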